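This account rests on a few compounds, and the source may have more. Where it says the series, first, only, none or still open, it means among the compounds named here.

In a functional assay on HL-60 cells (Homo sapiens) for antiproliferative activity, read by sulforhodamine B assay, with a stated time of 72 h (on this read-out higher numbers stand for weaker inhibition and lower numbers for stronger inhibition), three hydrazone thiosemicarbazones have been measured. Compound 1 `CN(C)C(=S)N/N=C/c1ccc2cccnc2n1` gives 560 nM. Compound 3 `NC(=S)N/N=C/c1nc2ccccc2s1` reaches only the limit of the assay, reported as > 100000 nM. Compound 2 `Fc1ccccc1NC(=S)N/N=C/c1ccc2ccccc2n1` likewise sits at the limit, reported as > 100000 nM, so no number is known for it; this is the limit of > 100000 nM in this assay, at which 2 of the 3 values shown sit. Compound 4 `S=C(N/N=C/c1ccc2ccccc2n1)Nc1ccccc1` differs from compound 2 in one place: hydrogen in place of fluoro on an aromatic carbon. Going by the values given here, since only a limit stands for compound 2, no measured step exists to guide the change, and removing the fluoro is a small change, so no step beyond the usual scatter is expected. Compound 4 is therefore estimated to remain at the limit, around 100000 nM, within 30000 nM to 300000 nM. The expected step is a number no higher from compound 2 to compound 4 (the limit leaves the size open).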

Compound 4, half-maximal inhibitory concentration: 9130 nM
Estimate against measurement, compound 4: 11-fold (1.04 log units) above, outside the stated range (below it).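

In this assay, the change from 2-fluorophenyl to phenyl brings an at least 10-fold lower number from compound 2 to compound 4 (1.03 log units; beyond the scatter). This shows that the aromatic carbon ortho to a large group is a place where a single atom can decide whether the compound gives a measurable number at all. The value for compound 2 is only a limit, so the full size of this step stays unknown: the limit of > 100000 nM in this assay, at which 2 of the 4 values shown sit.

Going by these compounds, whether chloro, methyl or methoxy on that carbon would stay close to compound 4 or return to the limit remains open. So does the effect of fluoro elsewhere on the phenyl ring.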